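Swapping the aryl group on the ring nitrogen of a porcupine inhibitor

A few compounds are considered here, and "the series" means these few. Any claim that something is new, unique, unknown or untested is made for them only; others in the source may bear on it.

Among the compounds with values here, compound 1 `COc1ccccc1-n1c(SCC(=O)Nc2nc3ccc(C(F)(F)F)cc3s2)nc2c(c1=O)SCC2` is one of two compounds measured in an assay on L cells for inhibition of Protein-serine O-palmitoleoyltransferase porcupine (Mus musculus), read by reporter gene assay, with a stated time of 24 h; a lower number here means that less compound is needed, a higher number that more compound is needed for the effect; compound 1 gives 30 nM, the lower of the two numbers, yet it sits within the scatter of compound 2 `COc1ccccc1-n1c(SCC(=O)Nc2nc3ccc(Cl)cc3s2)nc2c(c1=O)SCC2`, which gives 50 nM. Within the data shown here, the only measured step, a 1.7-fold higher number from compound 1 to compound 2 (0.22 log units; within the scatter), changes a substituent on the fused ring and is within the scatter.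

Compound 3 `O=C(CSc1nc2c(c(=O)n1-c1ccc(F)cc1)SCC2)Nc1nc2ccc(C(F)(F)F)cc2s1` differs from compound 1 at another site: 4-fluorophenyl in place of 2-methoxyphenyl on an aromatic nitrogen. Among the measured compounds shown here, no measured step touches this position, so the two known values give no direct guidance; they only show that the shared core tolerates a small change elsewhere without a shift beyond the scatter. The expectation for compound 3 is therefore a modest loss at most, a 2.0-fold higher number from compound 1 to compound 3 (0.30 log units; within the scatter), with a wide range. Compound 3 is estimated at 60 nM in this assay, between 12 nM and 400 nM.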

Compound 3, half-maximal effective concentration: 100 nM
For compound 3 the middle estimate is 1.7-fold (0.22 log units) below the measured one; the measured number falls inside the stated range.
By their numbers in this assay, from the lowest: compounds 1, 2 and 3 (each within the scatter of the next, the first and the last beyond it).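

In this assay, within the data shown here, the aryl group on the aromatic nitrogen is changed for the first time, and 4-fluorophenyl in place of 2-methoxyphenyl gives a 3.3-fold higher number from compound 1 to compound 3 (0.52 log units; beyond the scatter). This step lies beyond the scatter, whereas the earlier step from chloro to trifluoromethyl's position on the other side of the molecule did not, so the number does respond to the group at this position, though modestly. Nothing measured here offers an explanation for the shift.

The single step removes the 2-methoxyphenyl and brings in the 4-fluorophenyl together, so the compounds shown cannot say which feature of the exchange matters, and a plain phenyl group would help to separate them. Also open, from the compounds shown here alone, is how an aryl group carrying an amine or a carboxylic acid would fare at this position.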